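Swapping a methyl for a cyano on the phenyl ring

A few compounds are considered here, and "the series" means these few. Any claim that something is new, unique, unknown or untested is made for them only; others in the source may bear on it.

Of the compounds shown here, two sharing one core have been measured in a functional assay for agonist activity at G protein-coupled receptor 88 (Homo sapiens), read by HTRF and cAMP accumulation; a higher number here means that more compound is needed for the effect, a lower number that less compound is needed. Compound 1 `CC[C@H](C)[C@H](N)CN(C(=O)[C@@H]1C[C@H]1c1cccc(Cl)c1)c1ccc(-c2ccccc2)cc1` gives 2200 nM. Compound 2 `CC[C@H](C)[C@H](N)CN(C(=O)[C@@H]1C[C@H]1c1cccc(C)c1)c1ccc(-c2ccccc2)cc1` gives 1200 nM. For the measured compounds named here, the only step between them, a 1.8-fold lower number from compound 1 to compound 2 (0.26 log units; within the scatter), is the exchange of chloro for methyl on an aromatic carbon, and it is too small to count as a real change. Compound 2 therefore holds the lower of the two numbers, but sits within the scatter of compound 1. Compound 3 `CC[C@H](C)[C@H](N)CN(C(=O)[C@@H]1C[C@H]1c1cccc(C#N)c1)c1ccc(-c2ccccc2)cc1` differs from compound 2 by cyano in place of methyl on an aromatic carbon, at the place that is meta to a large group. Going by the values given here, no measured step covers this change; the one step available, from chloro to methyl, was small, which suggests this position tolerates small groups without large shifts. The expected step of a 1.7-fold higher number from compound 2 to compound 3 (0.22 log units; within the scatter) is accordingly modest. Compound 3 is estimated at 2000 nM, with a range from 600 nM to 7000 nM.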

Compound 3, half-maximal effective concentration: 1600 nM
Estimate against measurement, compound 3: 1.3-fold (0.10 log units) above; low and high end bracket the measured number.
By their numbers in this assay, from the lowest: compounds 2, 3 and 1 (each within the scatter of the next).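

In this assay the new compound gives a 1.3-fold higher number from compound 2 to compound 3 (0.12 log units; within the scatter) and also a 1.4-fold lower number from compound 1 to compound 3 (0.14 log units; within the scatter), so cyano, with its triple bond and its hydrogen-bond acceptor, cannot be told apart from methyl or chloro on this aromatic carbon. The earlier pair compared only chloro and methyl, whereas the 3-cyanophenyl compound shows that a group with one more heavy atom than methyl and a different make-up also leaves the number within the scatter. No available data bear on why these three groups read alike.

As far as these compounds go, it remains open whether an amine, a carboxylic acid or a longer chain at this place would also leave the number within the scatter, and what plain hydrogen would give. No group shown here yet moves the number beyond the scatter.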